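Swapping the aryl group on the triazole of a terpenoid ester

This account rests on a few compounds, and the source may have more. Where it says the series, first, only, none or still open, it means among the compounds named here.

Measured compounds:
- Compound 1, `C/C(=C\CC/C(C)=C/CC[C@@H]1[C@@]2(C)CCC(=O)C(C)(C)[C@H]2CC[C@@]1(C)O)CC/C=C(\C)C(=O)OCc1cn(C[C@@H]2O[C@H](n3ccc(=O)[nH]c3=O)[C@H]3OC(C)(C)O[C@H]32)nn1`: 15300 nM
- Compound 2, `C/C(=C\CC/C(C)=C/CC[C@@H]1[C@@]2(C)CCC(=O)C(C)(C)[C@H]2CC[C@@]1(C)O)CC/C=C(\C)C(=O)OCc1cn(-c2ccc(Br)cc2)nn1`: > 150000 nM
- Compound 3, `C/C(=C\CC/C(C)=C/CC[C@@H]1[C@@]2(C)CCC(=O)C(C)(C)[C@H]2CC[C@@]1(C)O)CC/C=C(\C)C(=O)OCc1cn([C@@H]2C[C@@H](n3cc(C)c(=O)[nH]c3=O)O[C@H]2CO)nn1`: 35000 nM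

All three share the same terpenoid ester core, and they differ only in the group attached to the aromatic nitrogen of the triazole. In a functional assay on A549 cells (Homo sapiens) for antiproliferative activity, read by MTT assay, with a stated time of 48 h (on this read-out higher numbers stand for weaker inhibition and lower numbers for stronger inhibition), compound 1 gives 15300 nM and compound 3 gives 35000 nM. Compound 2, which carries a 4-bromophenyl at that position, reaches only the limit of > 150000 nM in this assay, so no number is known for it. Among the three, compound 2 therefore stands where the assay stops reporting, as shown by the limit of > 150000 nM in this assay, at which 1 of the 3 values shown sits.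

The next compound, compound 4, `COc1ccccc1-n1cc(COC(=O)/C(C)=C/CC/C(C)=C/CC/C(C)=C/CC[C@@H]2[C@@]3(C)CCC(=O)C(C)(C)[C@H]3CC[C@@]2(C)O)nn1`, has not yet been tested in this assay. It differs from compound 2 in one place: 2-methoxyphenyl in place of 4-bromophenyl on an aromatic nitrogen

Among the measured compounds shown here, since compound 2 gives only a limit, no measured step from it can be sized, and the two nucleoside-bearing compounds give no guide to an aryl-for-aryl exchange. Compound 4 is expected to stay near the limit, and the step of an at least 1.5-fold lower number from compound 2 to compound 4 (0.17 log units; that floor lies within the scatter) is estimated to be no more than the scatter. Compound 4 is expected to give about 100000 nM, within 30000 nM to 300000 nM in this assay.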

Compound 4, half-maximal inhibitory concentration: > 150000 nM
Compound 4: only a limit was reported (the forecaster's own chance of this, stated with the estimate: 55%); middle value at least 1.5-fold (0.17 log units) away from the limit.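

In this assay compound 4 gives > 150000 nM, which is a limit and not a number. Compound 2 also gives only a limit, so no step between compound 2 and compound 4 can be read: the limit of > 150000 nM in this assay, at which 2 of the 4 values shown sit.

Still open, as far as these compounds go, is whether 2-methoxyphenyl and 4-bromophenyl differ at all in this assay, since neither compound 2 nor compound 4 has a number there.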